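The source may report more compounds than this note shows. Statements on the series, on what has been measured and on what is new or still open speak of the compounds shown alone.

The measured compounds:
Compound 1, `CNC(=O)c1ccc(NCc2cncn2Cc2ccc(-c3ccccc3)cc2N)cc1-c1ccccc1`: in a toxicity assay on NIH3T3 cells (Mus musculus) for cytotoxicity, read by resazurin assay (a lower number here means that less compound is needed, a higher number that more compound is needed for the effect), compound 1 gives only a limit, > 1000 nM.
Compound 2, `CNC(=O)c1ccc(NCc2cncn2Cc2ccc(-c3ccccc3)cc2)cc1-c1ccccc1`: in this assay compound 2 gives only a limit, > 1000 nM.
Compound 3, `COC(=O)c1ccc(NCc2cncn2Cc2ccc(F)cc2)cc1-c1ccccc1`: in this assay compound 3 has no reported result, "not determined" (no result reported).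

Compound 2 thus stands at a limit, with one further value also a limit and one entry without a number. Within the data shown here, the only step between measured compounds, a step that the two limits leave unreadable from compound 1 to compound 2, cannot be read because both ends sit at the limit of > 1000 nM in this assay, at which 2 of the 3 values shown sit.

Compound 4, `c1ccc(-c2ccc(Cn3cncc3CNc3ccc(-c4noc5ccccc45)c(-c4ccccc4)c3)cc2)cc1`, has not been measured. It differs from compound 2 in one place: a group of 9 heavy atoms (7 carbon, 1 nitrogen, 1 oxygen; one five-membered aromatic ring with 2 hetero atoms, one six-membered aromatic ring of carbon only) in place of a group of 4 heavy atoms (2 carbon, 1 nitrogen, 1 oxygen; no ring), on an aromatic carbon. Among the measured compounds shown here, no measured step bears on a change of this kind, and the step from compound 1 to compound 2 gives no readable size, so there is no evidence for a step beyond the scatter in either direction.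

For compound 4 the estimated step that the limit leaves unreadable from compound 2 to compound 4 is therefore taken as small. Compound 4 is expected to give about 1500 nM, in a range from 400 nM to 6000 nM.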

Compound 4, half-maximal effective concentration: > 10000 nM
Compound 4: no number, only a limit; the forecaster's own chance of this, stated with the estimate: 60%; at least 6.6-fold (0.82 log units) between middle value and limit.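

In this assay compound 4 gives only a limit, > 10000 nM. Compound 2 also gives only a limit, > 1000 nM, so the step between compound 2 and compound 4 cannot be read. The compounds shown leave open where the half-maximal effective concentration of either compound actually lies, and whether the change of group alters it at all.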